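The source may hold more compounds than are shown below. What is called first, only, known or untested is meant among the compounds shown, and "the series" means these compounds.

Measured so far:
Compound 1 `CCOC(=O)c1c(-c2cccc(C)c2)[nH]c2cc(OC)ccc2c1=O` — > 21500 nM
Compound 2 `CCCOc1cccc(-c2[nH]c3cc(OC)ccc3c(=O)c2C(=O)OCC)c1` — > 21500 nM
Compound 3 `CCCCOc1cccc(-c2[nH]c3cc(OC)ccc3c(=O)c2C(=O)OCC)c1` — > 21500 nM

Each of these three values in an ADME assay on BJ cells (Homo sapiens) for cytotoxicity, read by luminescence, with a stated time of 72 h (on this read-out lower numbers stand for an effect already at smaller amounts and higher numbers for an effect only at larger amounts of compound), is a limit of the assay rather than a number. Compound 2 therefore stands at the edge of what was measured, where all three compounds sit (the limit of > 21500 nM in this assay, at which 3 of the 3 values shown sit). Compound 4 `CCOC(=O)c1c(-c2cccc(NC(C)=O)c2)[nH]c2cc(OC)ccc2c1=O` differs from compound 2 by one change: acetamido in place of propoxy on an aromatic carbon. The steps measured so far, a step that the two limits leave unreadable from compound 1 to compound 2, a step that the two limits leave unreadable from compound 1 to compound 3 and a step that the two limits leave unreadable from compound 2 to compound 3, all run between limits and carry no readable size, so they give no direction for the new change. Going by the values given here, with every value so far at the limit, compound 4 is expected to sit there as well, the estimated step that the limit leaves unreadable from compound 2 to compound 4 being no step beyond the scatter. The estimate for compound 4 is 30000 nM, within 10000 nM to 100000 nM.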

Compound 4, half-maximal effective concentration: > 21500 nM
Compound 4 ended at the assay's limit (the forecaster's own chance of this, stated with the estimate: 85%); the middle value is on the limit's open side.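

Going by these compounds alone, no step from compound 1, compound 2 or compound 3 to compound 4 can be read, since each value is a limit and not a number: the limit of > 21500 nM in this assay, at which 4 of the 4 values shown sit. On these data alone, the concentration at which any of these four compounds would show an effect remains open.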